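Cyclopropyl aryl swap on the weakest member of the series

The compounds below may be only part of what the source reports. "The series", "measured", "known", "first", "only" and "open" are said of these compounds alone.

Compound 3 `CC[C@H](C)[C@H](N)CN(C(=O)[C@@H]1C[C@H]1c1cccc(Cl)c1)c1ccc(-c2ccccc2)cc1` is the least potent of the three measured compounds in a functional assay for agonist activity at G protein-coupled receptor 88 (Homo sapiens), read by HTRF and cAMP accumulation; on this read-out lower numbers stand for an effect already at smaller amounts and higher numbers for an effect only at larger amounts of compound: compound 3 gives 2200 nM, while compound 1 `CC(C)(N)CN(C(=O)[C@@H]1C[C@H]1c1ccccc1)c1ccc(-c2ccccc2)cc1` gives 1.4 nM and compound 2 `CC(C)(C)[C@H](N)CN(C(=O)[C@@H]1C[C@H]1c1ccccc1)c1ccc(-c2ccccc2)cc1` gives 11 nM. Among the compounds with values here, the only single-point step available, a 7.9-fold higher number from compound 1 to compound 2 (0.90 log units; beyond the scatter), concerns the amine-bearing chain and not the aryl on the cyclopropane; compound 3 differs from compound 2 in two places, so its gap to compound 2 cannot be assigned to either one.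

Compound 4 `CC[C@H](C)[C@H](N)CN(C(=O)[C@@H]1C[C@H]1c1nccs1)c1ccc(-c2ccccc2)cc1` differs from compound 3 by 1,3-thiazol-2-yl in place of 3-chlorophenyl on a saturated ring carbon. Within the data shown here, no measured pair in this assay changes the aryl on the cyclopropane, so no step bears directly on this change, and the expectation rests on compound 3 alone. With compound 3 at 2200 nM as the anchor, the step of a 1.4-fold higher number from compound 3 to compound 4 (0.13 log units; within the scatter) is expected to stay within the scatter, in either direction. Compound 4 is therefore estimated at 3000 nM, with a range from 600 nM to 15000 nM.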

Compound 4, half-maximal effective concentration: 210 nM
Estimate against measurement, compound 4: 14-fold (1.15 log units) above; measured number below the stated range.
By their numbers in this assay, from the lowest: compound 1; then compound 2; then compound 4; then compound 3.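

In this assay, within the data shown here, the group on the saturated ring carbon moves the number on its own: 1,3-thiazol-2-yl in place of 3-chlorophenyl gives a 10-fold lower number from compound 3 to compound 4 (1.02 log units; beyond the scatter), the first single-place step at this position, as the earlier step concerned only the amine-bearing chain. The step also shows that a five-membered aromatic ring with 2 hetero atoms is accepted here in place of a six-membered aromatic ring of carbon only. Nothing measured explains the step, and this single pair does not separate the loss of the chlorine from the change of ring.

Plain phenyl on this ring carbon, with the amine chain of compound 4, would separate those two parts of the change, while 1,3-oxazol-2-yl or pyridin-2-yl would show whether the gain is tied to thiazole itself. On these data alone, whether the step carries over to the amine chains of compound 1 and compound 2 also stays open.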